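Acetyl variant of compound 1 in the edema series

A few compounds are considered here, and "the series" means these few. Any claim that something is new, unique, unknown or untested is made for them only; others in the source may bear on it.

Measured in a functional assay on the whole organism (strain albino) for inhibition, with Rattus norvegicus as the target, read by paw edema, with stated times of 30 min and 5 h, at a dose of 0.28 mmol/kg by the oral route; on this read-out lower numbers stand for less inhibition and higher numbers for more inhibition at the one dose given (going by the name of the read-out):
compound 1 `COc1cc(-c2nnc(SCC(=O)Nc3ccc(/C(C)=N/O)cc3)n2-c2ccccc2)cc(OC)c1OC` — 70%
compound 2 `C/C(=N\O)c1ccc(NC(=O)CSc2nnc(-c3ccccc3)n2-c2ccccc2)cc1` — 66%

Compound 1 carries the higher of the two numbers, yet the step of a number 4 percentage points lower from compound 1 to compound 2 (within the scatter) lies within the scatter, so compound 1 and compound 2 cannot be told apart on this read-out. That single step concerns the aryl group on the shared core, not the anilide end.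

Compound 3 `COc1cc(-c2nnc(SCC(=O)Nc3ccc(C(C)=O)cc3)n2-c2ccccc2)cc(OC)c1OC` differs from compound 1 only at the anilide end: a group of 3 heavy atoms (2 carbon, 1 oxygen; no ring) in place of a group of 4 heavy atoms (2 carbon, 1 nitrogen, 1 oxygen; no ring), on an aromatic carbon. Among the compounds with values here, no measured step touches this position, so nothing speaks for a shift beyond the scatter in either direction; the one step known, phenyl for 3,4,5-trimethoxyphenyl, was itself within the scatter. The step of a number 5 percentage points lower from compound 1 to compound 3 (within the scatter) is therefore expected to stay within the scatter. For compound 3 the estimate is 65%, with a range from 50% to 78%.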

Compound 3, a percentage reported as inhibition, in the whole organism at one dose (the size of the read-out at that dose, not a potency): 63%
The estimate for compound 3 lay 2 percentage points above the measured number; low and high end bracket the measured number.
By their numbers in this assay, from the lowest: compounds 3, 2 and 1 (each within the scatter of the next).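

Acetyl in place of the group of 4 heavy atoms at the anilide end gives a number 7 percentage points lower from compound 1 to compound 3 (within the scatter) in this assay, the first measured step at this position. Although the exchange takes this place from 1 hydrogen-bond donor to 0 and from 2 hydrogen-bond acceptors to 1, compound 1 and compound 3 cannot be told apart on this read-out at the one dose given, so neither the donor nor the nitrogen of the leaving group is shown to matter here. No supporting measurement bears on this result.

From the compounds shown here alone, whether an amine, a carboxylic acid or a longer chain on this aromatic carbon would move the number beyond the scatter remains open. Also open, going by these compounds, is whether acetyl would give a similar number with phenyl in place of 3,4,5-trimethoxyphenyl on the shared core.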